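Chloro on the pyrazole-borne phenyl across two cores

A few compounds are considered here, and "the series" means these few. Any claim that something is new, unique, unknown or untested is made for them only; others in the source may bear on it.

Compound 1 `O=C(Nc1ccccc1)Nc1ccc(Oc2ncnc3c2cnn3-c2ccccc2)cc1` and compound 2 `O=C(Nc1ccccc1)Nc1ccc(Oc2ncnc3c2cnn3-c2ccc(Cl)cc2)cc1` share one core; compound 3 `Clc1ccc(COc2ccc(Nc3ncnc4c3cnn4-c3ccccc3)cc2)cc1` and compound 4 `Clc1ccc(COc2ccc(Nc3ncnc4c3cnn4-c3ccc(Cl)cc3)cc2)cc1` share another. The difference between the two cores is not broken down here.

In a functional assay on MCF7 cells (Homo sapiens) for cytotoxicity, read by sulforhodamine B assay, with a stated time of 72 h (on this read-out higher numbers stand for weaker inhibition and lower numbers for stronger inhibition), compound 1 returns only a limit of the assay, > 100000 nM; this is the limit (the limit of > 100000 nM in this assay, at which 1 of the 3 values shown sits). In this assay compound 2 gives 82500 nM. The change between them, (chloro in place of hydrogen on an aromatic carbon), made a step of an at least 1.2-fold lower number from compound 1 to compound 2 (0.08 log units; that floor lies within the scatter); since one end is a limit, the true size of that step is not fixed.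

In this assay compound 3 gives 4360 nM, the lowest number among the measured compounds. The change from compound 3 to compound 4 is chloro in place of hydrogen on an aromatic carbon, the same change as from compound 1 to compound 2, at the same place.

For compound 4 the expected step is a 1.5-fold lower number from compound 3 to compound 4 (0.16 log units; within the scatter), which rests on the step of an at least 1.2-fold lower number from compound 1 to compound 2 (0.08 log units; that floor lies within the scatter), pointing to a small move at most. Compound 4 is therefore estimated at 3000 nM, between 1000 nM and 9000 nM.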

Compound 4, half-maximal inhibitory concentration: > 100000 nM
Compound 4 ended at the assay's limit; the forecaster's own chance of this, stated with the estimate: 5%; middle value at least 33-fold (1.52 log units) away from the limit.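

On the core of compound 3 in this assay, phenyl to 4-chlorophenyl gives an at least 22-fold higher number from compound 3 to compound 4 (1.36 log units; beyond the scatter), a step whose upper end is a limit of the assay and not a number. The change therefore does not carry over unaltered from one core to the other in this series: the same change on two cores in this assay, an at least 1.2-fold lower number (0.08 log units; that floor lies within the scatter) from compound 1 to compound 2 and an at least 22-fold higher number (1.36 log units; beyond the scatter) from compound 3 to compound 4, at least 27-fold (1.44 log units) apart, beyond the scatter of two such steps. For the compounds shown here, only two cores are compared and each step is a floor, so the true sizes stay unfixed, nothing follows for any third core, and the data do not show what makes the two cores differ, with values gathered at one limit: the limit of > 100000 nM in this assay, at which 2 of the 4 values shown sit.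

Left open is whether the jump belongs to chloro alone or also appears with fluoro, methyl or methoxy on the same ring of the core of compound 3. Equally open, as far as these compounds go, is which feature separating the two cores decides the outcome of the change.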